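The compounds below may be only part of what the source reports. "The series", "measured", "known", "first", "only" and "open" are said of these compounds alone.

Compound 1 `CN(C)C(=O)c1cc2cnc(Nc3ccc(C(=O)NCCCN=C=S)cc3)nc2n1C1CCCC1`: 91.2%
Compound 2 `CN(C)C(=O)c1cc2cnc(Nc3ccc(NC(=O)CCCCN=C=S)cc3)nc2n1C1CCCC1`: 82.5%
Compound 3 `CN(C)C(=O)c1cc2cnc(Nc3ccc(NC(=O)CCCCCN=C=S)cc3)nc2n1C1CCCC1`: 85%

In a functional assay on NCI-H1299 cells (Homo sapiens) for inhibition, read by CCK-8 assay, with a stated time of 72 h, tested at 10 uM (on this read-out lower numbers stand for a weaker effect and higher numbers for a stronger effect at the one concentration tested), compound 3 gives 85%. Its number sits between those of compound 1 and compound 2, and all three lie within the scatter of one another: the step of a number 2.5 percentage points higher from compound 2 to compound 3 (within the scatter) and the step of a number 6.2 percentage points lower from compound 1 to compound 3 (within the scatter) are both too small to carry meaning, as is a number 8.7 percentage points lower from compound 1 to compound 2 (within the scatter).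

Compound 4 `CN(C)C(=O)c1cc2cnc(Nc3ccc(N=C=S)cc3)nc2n1C1CCCC1` differs from compound 3 in one place: a group of 3 heavy atoms (1 carbon, 1 nitrogen, 1 sulfur; no ring) in place of a group of 11 heavy atoms (7 carbon, 2 nitrogen, 1 oxygen, 1 sulfur; no ring), on an aromatic carbon. The three measured steps all exchange one chain bearing an amide and an isothiocyanate for another of a different length, and none of them moves the read-out beyond the scatter. The step to compound 4 is of a different kind, since the amide and the chain leave altogether and only the isothiocyanate remains on the aromatic carbon. Among the compounds with values here, no measured pair shows what such a removal does in this assay, so the expectation rests on the observation that the chain length itself made no difference among compounds 1, 2 and 3.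

For compound 4 the read-out in this assay is therefore expected to stay near that of compound 3, as a step of a number 7 percentage points lower from compound 3 to compound 4 (within the scatter), with wide uncertainty because the amide is absent in compound 4 only. The estimate for compound 4 is 78%, with a range from 50% to 95%.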

Compound 4, a percentage reported as inhibition, at one concentration (the size of the read-out at that concentration, not a potency): 83.7%
For compound 4 the middle estimate is 5.7 percentage points below the measured one; measured number inside the range.
By their numbers in this assay, from the lowest: compounds 2, 4, 3 and 1 (each within the scatter of the next).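

In this assay, cutting the substituent back to the bare isothiocyanate on the aromatic carbon, para to a large group, gives a number 1.3 percentage points lower from compound 3 to compound 4 (within the scatter) and a number 1.2 percentage points higher from compound 2 to compound 4 (within the scatter) and a number 7.5 percentage points lower from compound 1 to compound 4 (within the scatter) and so leaves the read-out within the scatter of all three chain compounds. The earlier compounds shown here only exchanged one chain for another and always kept an amide, so they could not show what compound 4 shows: at this position, neither the amide nor the chain is required to keep the inhibition at the one concentration tested within that scatter. Nothing measured alongside these numbers accounts for this result.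

Every compound shown carries the isothiocyanate, and what an amine or an acetamide in its place on this aromatic carbon would do in this assay stays open. Going by these compounds, a single concentration gives the size of an effect and not a potency, so it also stays open whether these four compounds would separate across a full concentration series.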